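Sulfonyl substituent variation on the shared core

The compounds below may be only part of what the source reports. "The series", "measured", "known", "first", "only" and "open" are said of these compounds alone.

Measured compounds:
compound 1 `CN1CCN(c2ccc(C3=NN(C(=O)CCCl)C(c4ccc(N(C)C)cc4)C3)cc2)CC1`: -0.2%
compound 2 `CN1CCN(c2ccc(C3=NN(C(=O)/C=C/c4ccccc4)C(c4ccc(N(C)C)cc4)C3)cc2)CC1`: 81%
compound 3 `CN1CCN(c2ccc(C3=NN(S(C)(=O)=O)C(c4ccc(N(C)C)cc4)C3)cc2)CC1`: -1.3%

In a functional assay on NCI-H1975 cells (Homo sapiens) for inhibition, read by sulforhodamine B assay, tested at 10 uM (a higher number here means more inhibition at the concentration tested (going by the name of the read-out), a lower number less inhibition), compound 3 gives the lowest of the three numbers; it sits within the scatter of compound 1 and far below compound 2, the gap being a number 82.3 percentage points lower from compound 2 to compound 3 (beyond the scatter).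

Compound 4 `CN1CCN(c2ccc(C3=NN(S(=O)(=O)c4ccc(Br)cc4)C(c4ccc(N(C)C)cc4)C3)cc2)CC1` differs from compound 3 in one place: 4-bromophenyl in place of methyl on a sulfonyl sulfur. Among the compounds with values here, no measured step changes the group on a sulfonyl sulfur, so the bearing of earlier steps is indirect. The nearest analogy is a number 81.2 percentage points higher from compound 1 to compound 2 (beyond the scatter), where an aromatic ring entered on a carbonyl carbon and this assay rose strongly; the reverse, a number 82.3 percentage points lower from compound 2 to compound 3 (beyond the scatter), shows the same ring leaving together with the carbonyl. The step of a number 1.1 percentage points lower from compound 1 to compound 3 (within the scatter) shows that exchanging the small chloroethyl-carbonyl for methylsulfonyl changes nothing beyond the scatter.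

An aromatic ring entering on the sulfonyl sulfur of compound 4 is therefore expected to raise this assay, but with wide uncertainty since the attachment differs; the estimated step is a number 31.3 percentage points higher from compound 3 to compound 4 (beyond the scatter). For compound 4 the estimate is 30%, within -5% to 75%.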

Compound 4, a percentage reported as inhibition, at one concentration (the size of the read-out at that concentration, not a potency): 70.8%
Compound 4: middle estimate off by 40.8 percentage points, on the low side; low and high end bracket the measured number.
By their numbers in this assay, from the lowest: compounds 3 and 1 (each within the scatter of the next); then compound 4; then compound 2.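

In this assay the group on the sulfonyl sulfur proves decisive, with a number 72.1 percentage points higher from compound 3 to compound 4 (beyond the scatter) for 4-bromophenyl in place of methyl, so a low number is not fixed by the sulfonyl link itself. A carbonyl link is also not required for a high number: (4-bromophenyl)sulfonyl stays close to (2-phenylethenyl)carbonyl, with a number 10.2 percentage points lower from compound 2 to compound 4 (beyond the scatter) as a modest step that is still beyond the scatter. Against (2-chloroethyl)carbonyl the picture is the same as against methylsulfonyl, with a number 71 percentage points higher from compound 1 to compound 4 (beyond the scatter) as a large step on the shared core. Nothing measured bears on the reason for these steps.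

As far as these compounds go, it remains open whether the bromine contributes or the six-membered aromatic ring alone carries the rise, which an unsubstituted phenyl on the sulfonyl sulfur would address. A 4-methoxyphenyl or a cyclohexyl at the same place would further test how much depends on the ring and its substituent.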